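Adding a Methyl to the Ring Nitrogen of Compound 2

The source may report more compounds than this note shows. Statements on the series, on what has been measured and on what is new or still open speak of the compounds shown alone.

In a functional assay on B16 cells (Mus musculus) for inhibition, read by MTT assay, with a stated time of 72 h (a lower number here means a stronger inhibitor, a higher number a weaker inhibitor), compound 1 `COc1cc(/C=C2\CNC/C(=C\c3cc(OC)cc(OC)c3)C2=O)cc(OC)c1` gives 300 nM while compound 2 `CCN(CC)c1ccc(/C=C2\CNC/C(=C\c3ccc(N(CC)CC)cc3)C2=O)cc1` gives 1500 nM and compound 3 `CCN(CC)c1ccc2cc(/C=C3\CNC/C(=C\c4cc5ccc(N(CC)CC)cc5oc4=O)C3=O)c(=O)oc2c1` gives 44000 nM as its result. Compound 2 therefore holds the middle place, weaker than compound 1 and stronger than compound 3, with both gaps beyond the usual scatter. Compound 4 `CCN(CC)c1ccc(/C=C2\CN(C)C/C(=C\c3ccc(N(CC)CC)cc3)C2=O)cc1` differs from compound 2 in one place: methyl in place of hydrogen on an amine nitrogen in a ring with methyl in place of hydrogen on an amine nitrogen in a ring. Among the measured compounds shown here, no measured pair shows this change, so the expectation rests on little evidence. The expected step is a 1.3-fold lower number from compound 2 to compound 4 (0.10 log units; within the scatter) and would stay within the scatter. For compound 4 the estimated value is 1200 nM with 450 nM to 3500 nM as its expected range.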

Compound 4, half-maximal inhibitory concentration: 33000 nM
Beside the measured number, compound 4's estimate is 28-fold (1.44 log units) below it, and the stated range ends below it.
By their numbers in this assay, from the lowest: compound 1; then compound 2; then compounds 4 and 3 (each within the scatter of the next).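

In this assay, the ring nitrogen proves to be a sensitive position: methyl in place of the hydrogen on this amine nitrogen brings a 22-fold higher number from compound 2 to compound 4 (1.34 log units; beyond the scatter). Among the compounds shown here, no earlier pair of compounds differed at this nitrogen, so this is the first sign that a single added carbon here can cost much of the activity. No measurement at hand accounts for the loss. As far as these compounds go, whether a longer chain such as ethyl, or an acetyl group, on this nitrogen has a similar effect remains open, as does whether the same methyl change would cost as much on compound 1.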